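The source may report more compounds than this note shows. Statements on the series, on what has been measured and on what is new or still open speak of the compounds shown alone.

Three compounds have been measured in an ADME assay on RAW264.7 cells (Mus musculus) for cytotoxicity, read by MTT assay, with a stated time of 48 h; on this read-out lower numbers stand for higher toxicity in this test and higher numbers for lower toxicity in this test:
compound 1, `CC(=O)OC[C@H]1O[C@H](OC[C@H](Cn2cc(COc3ccc(-c4noc(NC5CCCCC5)n4)cc3)nn2)OC(C)=O)C=C[C@@H]1OC(C)=O`, gives 33.3 ug/mL;
compound 2, `C#CCN(c1nc(-c2ccc(Cl)cc2)no1)C1CCCCC1`, gives 15.1 ug/mL;
compound 3, `CC(=O)OC[C@H]1O[C@H](OC[C@@H](Cn2cc(CN(c3nc(-c4ccc(C)cc4)no3)C3CCCCC3)nn2)OC(C)=O)C=C[C@@H]1OC(C)=O`, gives 45.3 ug/mL.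

Among these three, compound 2 gives the lowest number in this assay and so is the most toxic of the three; its nearest neighbour is compound 1 and its furthest is compound 3, and both gaps lie beyond the usual scatter. Compound 4, `C#CCN(c1nc(-c2ccc(Br)cc2)no1)C1CCCCC1`, has not yet been measured. It differs from compound 2 in one place: bromo in place of chloro on an aromatic carbon. Among the compounds with values here, no measured pair here shows what this kind of exchange does, so no step of a known size can be read off. Such a swap of one halogen for another is usually a small change, and for compound 4 the expected step of a 1.1-fold lower number from compound 2 to compound 4 (0.03 log units; within the scatter) is none beyond the scatter. Compound 4 is therefore estimated at 14 ug/mL, with a likely range from 7 ug/mL to 28 ug/mL.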

Compound 4, half-maximal cytotoxic concentration: 15.7 ug/mL
Estimate against measurement, compound 4: 1.1-fold (0.05 log units) below, within the range that was stated.
By their numbers in this assay, from the lowest: compounds 2 and 4 (each within the scatter of the next); then compounds 1 and 3 (each within the scatter of the next).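

In this assay the exchange of chloro for bromo, on an aromatic carbon para to a large group, leaves the read-out within the scatter (a 1.0-fold higher number from compound 2 to compound 4 (0.02 log units; within the scatter)). Within the data shown here, this is the first measured pair that differs in one place, and at this position 4-chlorophenyl and 4-bromophenyl cannot be told apart. Nothing measured here explains this result. As far as these compounds go, whether an amine or a carboxylic acid at this position would also leave the read-out unchanged remains open. So does whether this halogen exchange would behave the same way in the larger compounds 1 and 3.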